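The compounds below may be only part of what the source reports. "The series", "measured", "known", "first", "only" and "open" are said of these compounds alone.

Measured compounds:
compound 1 `c1ccc(-c2cc3n(n2)CCCC3)nc1`, which gives 1290 nM in a functional assay on HEK293 cells for negative allosteric modulation of metabotropic glutamate receptor 5 (Rattus norvegicus), read by FLIPR and calcium flux, with a stated time of 170 s; a lower number here means a stronger inhibitor, a higher number a weaker inhibitor;
compound 2 `Clc1cccc(-c2cc3n(n2)CCCC3)n1`, which in this assay gives 1520 nM;
compound 3 `N#Cc1ccc(CC(=O)c2cc3n(n2)CCCC3)nc1`, which in this assay gives 53 nM.

The step from compound 1 to compound 2 is a 1.2-fold higher number from compound 1 to compound 2 (0.07 log units; within the scatter); the change is chloro in place of hydrogen on an aromatic carbon. Compound 3 stands lowest of the three, with compound 1 nearest and compound 2 furthest; the difference between the core of compound 3 and the core of compound 1 is not broken down here.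

Compound 4 `N#Cc1ccc(CC(=O)c2nn3c(c2Cl)CCCC3)nc1` has not yet been measured. It differs from compound 3 by chloro in place of hydrogen on an aromatic carbon. Within the data shown here, this is the same kind of change as the one from compound 1 to compound 2, but the place is not the same: in compound 2 the chloro sits on a six-membered aromatic ring with 1 nitrogen, next to the ring nitrogen, whereas in compound 4 it sits on a five-membered aromatic ring with 2 nitrogen, part of a fused system, next to the ring atom that bears a fused ring and next to the ring atom that bears a large group. Because the earlier chloro step a 1.2-fold higher number from compound 1 to compound 2 (0.07 log units; within the scatter) stayed within the scatter, the step from compound 3 to compound 4 is expected to be small as well, about a 1.5-fold higher number from compound 3 to compound 4 (0.18 log units; within the scatter), with the different place leaving the direction uncertain. Compound 4 is therefore estimated to give 80 nM in this assay, expected to lie between 25 nM and 250 nM.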

Compound 4, half-maximal inhibitory concentration: 108 nM
Compound 4: middle estimate off by 1.4-fold (0.13 log units), on the low side; the range from low to high includes it.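

In this assay, chloro in place of hydrogen on the five-membered aromatic ring gives a 2.0-fold higher number from compound 3 to compound 4 (0.31 log units; beyond the scatter), a modest step that takes the number up. Set beside the earlier chloro step on the other core, the two steps cannot be told apart: the same change on two cores in this assay, a 1.2-fold higher number (0.07 log units; within the scatter) from compound 1 to compound 2 and a 2.0-fold higher number (0.31 log units; beyond the scatter) from compound 3 to compound 4, 1.7-fold (0.24 log units) apart, within the scatter of two such steps. This is consistent with the change carrying over between these two cores with little effect, but the chloro also sits on a different ring in each pair, so the comparison cannot separate the role of the core from that of the place, and two pairs set no rule for the wider series.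

The compounds shown leave open whether chloro on the five-membered aromatic ring of compound 1 would give a step of like size. They also leave open how another small group on that same aromatic carbon, such as fluoro or methyl, would compare with chloro or hydrogen.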